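This account rests on a few compounds, and the source may have more. Where it says the series, first, only, none or still open, it means among the compounds named here.

In a functional assay on SK-BR-3 cells (Homo sapiens) for antiproliferative activity (a lower number here means a stronger inhibitor, a higher number a weaker inhibitor), three compounds with a shared core differ only in the amino group on a saturated chain carbon, three bonds along the chain from an oxygen on an aromatic ring. Compound 1 `CC(C)=CCc1cc(C(=O)Nc2cc3ccc(OCCCN4CCCC4)c(C)c3oc2=O)ccc1O` gives 720 nM, and compound 2 `CCNCCCOc1ccc2cc(NC(=O)c3ccc(O)c(CC=C(C)C)c3)c(=O)oc2c1C` gives 720 nM. Compound 3 `CC(C)=CCc1cc(C(=O)Nc2cc3ccc(OCCCN(C(C)C)C(C)C)c(C)c3oc2=O)ccc1O` gives 1600 nM, the highest number of the three, which makes it the weakest inhibitor so far.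

Compound 4 `CC(C)=CCc1cc(C(=O)Nc2cc3ccc(OCCCNC(C)(C)C)c(C)c3oc2=O)ccc1O` has not yet been measured. It carries (tert-butyl)amino in place of diisopropylamino at that same place: (tert-butyl)amino in place of diisopropylamino on a saturated chain carbon, three bonds along the chain from an oxygen on an aromatic ring.

Going by the values given here, three measured steps bear on this change. Replacing pyrrolidin-1-yl with ethylamino gave no change at the digits printed from compound 1 to compound 2 (within the scatter). Diisopropylamino was the one group that moved the number, with a 2.2-fold higher number from compound 1 to compound 3 (0.35 log units; beyond the scatter) and a 2.2-fold higher number from compound 2 to compound 3 (0.35 log units; beyond the scatter), both modest. Read backwards, these two steps suggest that removing diisopropylamino could lower the number. However, (tert-butyl)amino itself has never been tested, so only part of that modest gap is expected to be recovered.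

The expected change is a small one toward a lower number, a 1.6-fold lower number from compound 3 to compound 4 (0.20 log units; within the scatter). Compound 4 is estimated at 1000 nM, with an expected range of 550 nM to 1900 nM.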

Compound 4, half-maximal inhibitory concentration: 660 nM
Estimate against measurement, compound 4: 1.5-fold (0.18 log units) above; measured number inside the range.
By their numbers in this assay, from the lowest: compounds 4, 1 and 2 (each within the scatter of the next); then compound 3.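

In this assay, going by these compounds alone, putting (tert-butyl)amino in place of diisopropylamino gives a 2.4-fold lower number from compound 3 to compound 4 (0.38 log units; beyond the scatter) and so recovers the modest gap that compound 3 had opened, more fully than the earlier steps alone could show. The comparisons with the other two amines give a 1.1-fold lower number from compound 2 to compound 4 (0.04 log units; within the scatter) and a 1.1-fold lower number from compound 1 to compound 4 (0.04 log units; within the scatter) and place three different amino groups together at this position, leaving compound 3 as the only one that stands apart. The change goes from 7 heavy atoms to 5 and from 0 hydrogen-bond donors to 1, but nothing measured here ties either difference, or any other feature of these groups, to the shift in the number.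

On these data alone, with only four amino groups compared, it remains open what sets diisopropylamino apart from the others, and whether that feature is specific to this group. A dimethylamino group or a morpholine ring at the same place could show whether such amines fall with compounds 1, 2 and 4 or with compound 3, and a longer chain could show whether the same ranking holds when the amine sits further from the oxygen.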